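The compounds below may be only part of what the source reports. "The series", "measured", "known", "first", "only" and "open" are said of these compounds alone.

Measured compounds:
compound 1, `O=C(Nc1ncc([N+](=O)[O-])s1)c1ccc(Cl)cc1O`: compound 1 gives "not determined" (no result reported) in an ADME assay on HEK-293T cells (Homo sapiens) for cytotoxicity, read by MTT assay, tested at 100 uM; a higher number here means a weaker effect of the compound at the concentration tested, a lower number a stronger effect
compound 2, `CC(=O)Oc1c(Cl)cc(Cl)cc1C(=O)Nc1ncc([N+](=O)[O-])s1`: compound 2 gives 95.1%
compound 3, `CC(C)c1cc(C(=O)Nc2ncc([N+](=O)[O-])s2)c(O)c(C(C)C)c1`: compound 3 gives 7.1%

Of the two numbers available, compound 3 stands lowest; its nearest neighbour, compound 2, lies higher by a gap beyond the usual scatter, and compound 1 adds no number. Compound 2 and compound 3 differ in more than one place, so their values are set side by side without a single step between them.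

Compound 4, `CC(=O)Oc1c(C(=O)Nc2ncc([N+](=O)[O-])s2)cc(C(C)C)cc1C(C)C`, is the next entry for this assay. It differs from compound 3 in one place: acetyl in place of hydrogen on an oxygen on an aromatic ring. Among the compounds with values here, no step between measured compounds covers this change. Within the data shown here, the only pointer is that compound 2, which also carries an acetoxy group, gives 95.1%. An upward step beyond the scatter is therefore expected, a number 47.9 percentage points higher from compound 3 to compound 4 (beyond the scatter). Compound 4 is estimated at 55%, within a range from 10% to 95%.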

Compound 4, a percentage reported as activity, at one concentration (the size of the read-out at that concentration, not a potency): 20.6%
Estimate against measurement, compound 4: 34.4 percentage points above; low and high end bracket the measured number.
By their numbers in this assay, from the lowest: compound 3; then compound 4; then compound 2.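

In this assay, within the data shown here, going from hydroxy to acetoxy on the aromatic ring gives the first single-place step, a number 13.5 percentage points higher from compound 3 to compound 4 (beyond the scatter), and it lies beyond the scatter. The oxygen on the aromatic ring is therefore a place where a change moves the read-out, yet with the acetyl group in place compound 4 still gives a low 20.6% on this scale. Nothing at hand explains the step.

On these data alone, whether a propionyl group or a methyl group on that oxygen would move the read-out in the same direction remains open. As far as these compounds go, whether the same change gives a similar step on other substituted versions of the core also remains open.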